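Methyl removal on the saturated ring: clearance notes

A few compounds are considered here, and "the series" means these few. Any claim that something is new, unique, unknown or untested is made for them only; others in the source may bear on it.

Measured compounds:
compound 1, `Cc1cc(N(C)C(N)=O)cc(C)c1CCS(=O)(=O)N1CCC2(CC1)N=C([C@H]1CC[C@H](C)CC1)NC2=O`, 45 uL/min
compound 2, `Cc1cc(N2CCNC2=O)cc(C)c1CCS(=O)(=O)N1CCC2(CC1)N=C(C1CCCCC1)NC2=O`, 62 uL/min
compound 3, `Cc1ccccc1CCS(=O)(=O)N1CCC2(CC1)N=C(C1CCCCC1)NC2=O`, 100 uL/min

In an ADME assay on microsomes from liver (Homo sapiens) for metabolic stability, read by LC-MS, using NADPH, with a stated time of 30 min, tested at 1 uM (a higher number here means faster removal of the compound, a lower number slower removal), compound 1 gives 45 uL/min, the lowest of the three numbers. Its nearest neighbour is compound 2, whose value in this assay is 62 uL/min; that gap lies within the scatter, so no order between the two can be claimed. Compound 3 gives 100 uL/min in this assay, and its gap to compound 1 lies beyond the scatter. Within the data shown here, compound 2 and compound 3 both carry a cyclohexyl group and differ from each other elsewhere; no pair of measured compounds differs in a single place, so no isolated step is available.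

Compound 4, `Cc1cc(N(C)C(N)=O)cc(C)c1CCS(=O)(=O)N1CCC2(CC1)N=C(C1CCCCC1)NC2=O`, carries the change hydrogen in place of methyl on a saturated ring carbon relative to compound 1. The same difference, cut one bond further out, reads 4-methylcyclohexyl to cyclohexyl. Among the measured compounds shown here, no measured pair isolates this change, so the expectation rests on compound 1 alone. The step of no change at the digits printed from compound 1 to compound 4 (within the scatter) is expected to be small, with no direction beyond the scatter. Compound 4 is estimated at 45 uL/min in this assay, within a range of 25 uL/min to 80 uL/min.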

Compound 4, intrinsic clearance in a liver preparation (reported as CLH), per the amount of preparation that the assay uses in the Homo sapiens assay: 23 uL/min
Estimate against measurement, compound 4: 2.0-fold (0.29 log units) above; measured number below the stated range.
By their numbers in the Homo sapiens assay, from the lowest: compounds 4, 1, 2 and 3 (each within the scatter of the next, the first and the last beyond it).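

Among these compounds, with compound 4, hydrogen in place of methyl on a saturated ring carbon can be read on its own for the first time in the Homo sapiens assay: a 2.0-fold lower number from compound 1 to compound 4 (0.29 log units; within the scatter), so no effect of this change on removal can be claimed. The same compound gives a second isolated reading, at the aromatic carbon, where carbamoyl(methyl)amino in place of 2-oxoimidazolidin-1-yl gives, in the Homo sapiens assay, a 2.7-fold lower number from compound 2 to compound 4 (0.43 log units; beyond the scatter), a step that does stand clear of the scatter. In a physicochemical assay for solubility, read by HPLC, in phosphate buffer, at pH 6.5, tested at 1 mM (on this read-out lower numbers stand for lower solubility and higher numbers for higher solubility), compound 1 gives 99 ug/mL and compound 4 gives 290 ug/mL, so at this ring carbon the change registers in solubility rather than in removal: the measured solubility of compound 1, 99 ug/mL, and of compound 4, 290 ug/mL, a 2.9-fold higher number (0.47 log units; beyond the scatter)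

The compounds shown carry only hydrogen or methyl at this ring carbon. On these data alone, whether a longer chain such as ethyl, or a hydroxyl group, would follow the same course in either read-out remains open.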